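Oxazole ketone series: truncating the pyridyl arm

A few compounds are considered here, and "the series" means these few. Any claim that something is new, unique, unknown or untested is made for them only; others in the source may bear on it.

Measured so far, in an assay for inhibition of Fatty-acid amide hydrolase 1 (Rattus norvegicus); a higher number here means a weaker inhibitor, a lower number a stronger inhibitor:
compound 1 `O=C(CCc1ccc(-c2ccccc2)cc1)c1ncc(-c2ccncc2)o1` gives 2.3 nM
compound 2 `COC(=O)c1ccc(-c2cnc(C(=O)CCc3ccc(-c4ccccc4)cc3)o2)cn1` gives 0.6 nM

Compound 2 holds the lowest of the two numbers; its nearest neighbour is compound 1, and the step of a 3.8-fold lower number from compound 1 to compound 2 (0.58 log units; beyond the scatter) lies beyond the scatter. Compound 3 `COC(=O)c1cnc(C(=O)CCc2ccc(-c3ccccc3)cc2)o1` differs from compound 2 by methoxycarbonyl in place of 6-(methoxycarbonyl)pyridin-3-yl on an aromatic carbon. Going by the values given here, no measured step removes a ring at this place; the only step at this position, a 3.8-fold lower number from compound 1 to compound 2 (0.58 log units; beyond the scatter), exchanged one six-membered ring for another and was modest. The change to compound 3 goes further, leaving only the methoxycarbonyl group where a whole ring stood, so a rise in the number beyond the scatter is expected, with the step of a 13-fold higher number from compound 2 to compound 3 (1.12 log units; beyond the scatter) as the estimate. Compound 3 is therefore expected to give 8 nM in this assay, within a range from 1.5 nM to 40 nM.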

Compound 3, inhibition constant: 1.5 nM
Compound 3: the middle estimate sits 5.3-fold (0.73 log units) above what was measured; the measured number falls inside the stated range.
By their numbers in this assay, from the lowest: compound 2; then compounds 3 and 1 (each within the scatter of the next).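

In this assay a whole ring at this place proves dispensable for a low number: methoxycarbonyl alone, on the aromatic carbon next to the ring oxygen, costs only a modest step (a 2.5-fold higher number from compound 2 to compound 3 (0.40 log units; beyond the scatter)). Set against the pyridin-4-yl group, the same small group gives a difference within the scatter (a 1.5-fold lower number from compound 1 to compound 3 (0.19 log units; within the scatter)), so among these compounds a six-membered aromatic ring here does not by itself secure the lower number. No available data explain either step.

As far as these compounds go, it remains open whether the methoxycarbonyl group itself matters, which a carboxylic acid or a primary amide at this place would address. Also open, from the compounds shown here alone, is whether the methoxycarbonyl on the pyridine of compound 2 accounts for its lower number, which an unsubstituted pyridin-3-yl group would help separate.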